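Trimethoxyphenyl for fluorophenyl on the central chain carbon

The source may report more compounds than this note shows. Statements on the series, on what has been measured and on what is new or still open speak of the compounds shown alone.

Measured so far:
- compound 1, `COc1cccc(/C=C/C(=O)C(=Cc2ccc(F)cc2)C(=O)/C=C/c2cccc(OC)c2OC)c1OC`, 340 nM
- compound 2, `COc1cccc(/C=C/C(=O)C(=Cc2cc(OC)c(OC)c(OC)c2)C(=O)/C=C/c2cccc(OC)c2OC)c1OC`, 230 nM

In a functional assay on A549 cells (Homo sapiens) for antiproliferative activity, read by sulforhodamine B assay, with a stated time of 48 h (on this read-out lower numbers stand for stronger inhibition and higher numbers for weaker inhibition), compound 1 gives 340 nM, the highest of the two numbers in hand; its nearest neighbour is compound 2, which in this assay gives 230 nM. The two values sit within the scatter of each other, so no order between them can be read.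

Compound 3, `COc1cccc(/C=C/C(=O)C(=Cc2ccc(OC)c(OC)c2OC)C(=O)/C=C/c2cccc(OC)c2OC)c1OC`, is not yet measured in this assay. From compound 1 it differs as follows: 2,3,4-trimethoxyphenyl in place of 4-fluorophenyl on a double-bonded chain carbon bound to a double-bonded chain carbon.

Among the measured compounds shown here, the only measured step that bears on this change is a 1.5-fold lower number from compound 1 to compound 2 (0.17 log units; within the scatter), where another trimethoxyphenyl took the place of the same 4-fluorophenyl on the same chain carbon. That step stayed within the scatter. With the three methoxy groups merely arranged differently on the ring, no step beyond the scatter is expected here either; the estimate for compound 3 therefore puts a 1.1-fold lower number from compound 1 to compound 3 (0.05 log units; within the scatter).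

For compound 3 the expected value in this assay is 300 nM, with a range from 120 nM to 800 nM.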

Compound 3, half-maximal inhibitory concentration: 260 nM
Compound 3: middle estimate off by 1.2-fold (0.06 log units), on the high side; the range from low to high includes it.
By their numbers in this assay, from the lowest: compounds 2, 3 and 1 (each within the scatter of the next).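

In this assay, 2,3,4-trimethoxyphenyl in place of 4-fluorophenyl on a double-bonded chain carbon bound to a double-bonded chain carbon gives a 1.3-fold lower number from compound 1 to compound 3 (0.12 log units; within the scatter), so a second trimethoxyphenyl pattern at this position also stays within the scatter of the 4-fluorophenyl compound. Among the compounds shown here, the exchange of one trimethoxyphenyl pattern for the other gives a 1.1-fold higher number from compound 2 to compound 3 (0.05 log units; within the scatter), the first direct comparison of two methoxy arrangements here, and it separates neither of them, so compounds 1, 2 and 3 cannot be ordered and all three exchanges at this chain carbon remain within the scatter. Nothing available explains why these exchanges leave the number within the scatter.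

The compounds shown leave open whether an amine or a carboxylic acid on this ring, or a longer chain in place of the ring, would shift the number beyond the scatter. They also leave open whether the same picture at this position would hold with a change elsewhere in the shared core, which all three compounds carry unchanged.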